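An Untested Ring Swap Starting From Compound 3

The compounds below may be only part of what the source reports. "The series", "measured", "known", "first", "only" and "open" are said of these compounds alone.

Three compounds here share one core and differ only in the arm attached to it. In a functional assay on A2780 cells (Homo sapiens) for inhibition (on this read-out lower numbers stand for stronger inhibition and higher numbers for weaker inhibition), compound 1 `CCNC(=O)c1noc(-c2cc(C(C)C)c(O)cc2O)c1-c1cc(COCC(=O)OC)no1` gives "not determined" (no result reported). Compound 2 `CCNC(=O)c1noc(-c2cc(C(C)C)c(O)cc2O)c1-c1cc(CNC(=O)CC)no1` gives "not determined" (no result reported) in this assay; no number was reported for either of them. Compound 3 `CCNC(=O)c1noc(-c2cc(C(C)C)c(O)cc2O)c1-c1cc(C(=O)OCC)no1` is the only one with a measurement: in this assay compound 3 gives 9000 nM, which is weak inhibition, and since it is the sole number shown, there is no second value to set beside it.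

Compound 4 `CCNC(=O)c1noc(-c2cc(C(C)C)c(O)cc2O)c1-c1ccn(C(C)C)n1` has not been tested yet. It differs from compound 3 in one place: 1-isopropyl-1H-pyrazol-3-yl in place of 3-(ethoxycarbonyl)-1,2-oxazol-5-yl on an aromatic carbon. The group that leaves carries an ethoxycarbonyl, the group that enters carries an isopropyl on a ring nitrogen, and both are five-membered aromatic rings with two hetero atoms.

Among the compounds with values here, no pair of measured compounds shows how such a swap moves the read-out, so the data point in no direction. The expected step in this assay is a 1.5-fold lower number from compound 3 to compound 4 (0.18 log units; within the scatter), a change that could well lie within the scatter of repeated measurements. Compound 4 is therefore estimated to give about 6000 nM in this assay, with a range from 1500 nM to 25000 nM.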

Compound 4, half-maximal inhibitory concentration: 45 nM
Compound 4: the middle estimate sits 130-fold (2.12 log units) above what was measured, outside the stated range (below it).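

In this assay the arm on this aromatic carbon proves to matter a great deal: putting 1-isopropyl-1H-pyrazol-3-yl in place of 3-(ethoxycarbonyl)-1,2-oxazol-5-yl brings a 200-fold lower number from compound 3 to compound 4 (2.30 log units; beyond the scatter) and so moves the read-out far more than repeated measurements would scatter. Within the data shown here, with only a single number available earlier, nothing showed whether the read-out responded to a change here at all; now two arms that are each a five-membered aromatic ring with two hetero atoms are seen to behave very differently, so that shared ring type alone does not set the level of inhibition. Nothing shown here explains the size of this step.

This single pair changes the ring, removes the ethoxycarbonyl and adds the isopropyl all at once, so it cannot say which of these differences carries the gain. It also leaves open whether a methyl or a longer chain such as butyl on the same ring nitrogen would keep the stronger inhibition, and how a carboxylic acid or an amine on the pyrazole ring would read.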